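The compounds below may be only part of what the source reports. "The series", "measured", "known", "first", "only" and "open" are said of these compounds alone.

In a functional assay for inhibition, with Homo sapiens as the target (on this read-out lower numbers stand for stronger inhibition and higher numbers for weaker inhibition), compound 3 `CN(C)c1cccc(Nc2nccc(-c3ccncc3)n2)c1` gives 3700 nM, the higher of the two plain numbers measured. Among the compounds with values here, compound 2 `CN(C)c1cccc(Nc2nccc(-c3ccccn3)n2)c1` gives 400 nM, and the step of a 9.3-fold higher number from compound 2 to compound 3 (0.97 log units; beyond the scatter) is the only measured step between two compounds that differ in one place. Compound 1 `COc1cccc(Nc2nc(C)cc(-c3ccncc3)n2)c1` sits at a limit of this assay, > 24000 nM, not at a number. Compound 4 `Cc1cc(-c2ccncc2)nc(Nc2cccc(N(C)C)c2)n1` differs from compound 3 by methyl in place of hydrogen on an aromatic carbon. Within the data shown here, no measured step covers this change: compound 1 carries the same methyl but also differs elsewhere, so its limit cannot be read as the effect of the methyl alone. Compound 4 is therefore estimated at 8000 nM with a range of 2500 nM to 30000 nM. This estimate means a step of a 2.2-fold higher number from compound 3 to compound 4 (0.33 log units; beyond the scatter), expected to weaken inhibition, with wide uncertainty.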

Compound 4, half-maximal inhibitory concentration: > 24000 nM
Compound 4: only a limit was reported (the forecaster's own chance of this, stated with the estimate: 25%); middle value at least 3.0-fold (0.47 log units) from the limit.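

In this assay a single methyl in place of hydrogen, on the aromatic carbon next to the ring nitrogen, is enough to weaken inhibition clearly: the result is an at least 6.4-fold higher number from compound 3 to compound 4 (0.81 log units; beyond the scatter) and shows that this position is sensitive even to this small change. The full size of that step, and the step between compound 1 and compound 4, cannot be read because these compounds sit at a limit: the limit of > 24000 nM in this assay, at which 2 of the 4 values shown sit.

On these data alone, whether a fluorine atom or an amine at this position would also weaken inhibition stays open. So does whether methyl has the same effect with pyridin-2-yl, the group carried by compound 2, in place of pyridin-4-yl.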